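Aryl exchange on the five-membered ring nitrogen of compound 3

The source may report more compounds than this note shows. Statements on the series, on what has been measured and on what is new or still open speak of the compounds shown alone.

Measured so far in an assay on CHO-K1 cells for antagonist activity at transient receptor potential cation channel subfamily V member 1 (Homo sapiens), read by FLIPR; a lower number here means a stronger inhibitor, a higher number a weaker inhibitor:
compound 1 `CC1CCN(c2nc(C(F)(F)F)ccc2CNC(=O)C(C)c2ccc3c(c2)CCO3)CC1` — 29.7 nM
compound 2 `CC1CCN(c2nc(C(C)(C)C)ccc2CNC(=O)C(C)c2ccc3c(c2)CCC3)CC1` — 44 nM
compound 3 `CC(C(=O)NCc1cc(C(F)(F)F)nn1-c1cccc(C(F)(F)F)c1)c1ccc2c(c1)CCC2` — 7.5 nM

Compound 3 gives the lowest number of the three in this assay; compound 1 lies a step above it that is beyond the scatter, and compound 2 lies further above, also beyond the scatter. No two of these compounds differ in one place only, so none of the gaps between them can be tied to a single change; compound 3 carries a different core from compounds 1 and 2, and its values stand on their own.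

Compound 4 `CC(C(=O)NCc1cc(C(F)(F)F)nn1-c1ccc(F)c(Cl)c1)c1ccc2c(c1)CCC2` is built from compound 3 by one change: 3-chloro-4-fluorophenyl in place of 3-(trifluoromethyl)phenyl on an aromatic nitrogen. Going by the values given here, nothing among the measured compounds bears on this exchange, since compounds 1 and 2 hold no group on a five-membered ring nitrogen. The expectation is therefore a step from compound 3 to compound 4 in this assay of a 1.3-fold higher number from compound 3 to compound 4 (0.12 log units; within the scatter), that is, none beyond the scatter, in either direction. For compound 4 the estimate in this assay is 10 nM, with a range from 3 nM to 35 nM.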

Compound 4, inhibition constant: 14.7 nM
Estimate against measurement, compound 4: 1.5-fold (0.17 log units) below; the range from low to high includes it.
By their numbers in this assay, from the lowest: compounds 3 and 4 (each within the scatter of the next); then compounds 1 and 2 (each within the scatter of the next).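

In this assay the replacement of 3-(trifluoromethyl)phenyl by 3-chloro-4-fluorophenyl on the aromatic nitrogen gives a 2.0-fold higher number from compound 3 to compound 4 (0.29 log units; within the scatter) and so stays within the scatter. Going by these compounds alone, this is the first comparison that differs in one place only, and it shows that this position accepts both substituted phenyl groups with no separation between them in this assay. Nothing at hand explains why the two groups read alike.

Still open, on these data alone, is how this position responds to a group other than a substituted phenyl, such as an unsubstituted phenyl, a pyridine ring, a cyclohexyl ring or a chain carrying an amine. The gaps from compounds 3 and 4 to compounds 1 and 2 cannot be read, since those pairs differ in more than one place.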